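Halogen Variation on the Aromatic Ring: Compound 4

The source may report more compounds than this note shows. Statements on the series, on what has been measured and on what is new or still open speak of the compounds shown alone.

Compound 1 `COC(=O)[C@@]1(C)CC[C@@H]2C3=C1CC[C@@H](C)[C@]3(C)C[C@@H]1c3ccccc3N[C@H]21` is the parent of this set. Within the data shown here, in a functional assay on WiDr cells (Homo sapiens) for inhibition, read by sulforhodamine B assay, with a stated time of 48 h (on this read-out lower numbers stand for stronger inhibition of growth and higher numbers for weaker inhibition of growth), compound 1 gives 50000 nM, the highest of the three numbers known; the nearest is compound 2 `COC(=O)[C@@]1(C)CC[C@@H]2C3=C1CC[C@@H](C)[C@]3(C)C[C@@H]1c3cc(Cl)ccc3N[C@H]21`, which gives 48000 nM, and the furthest is compound 3 `COC(=O)[C@@]1(C)CC[C@@H]2C3=C1CC[C@@H](C)[C@]3(C)C[C@@H]1c3cc(F)ccc3N[C@H]21`, which gives 32000 nM. Both gaps lie within the scatter, so the three compounds read as alike on this read-out.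

Compound 4 `COC(=O)[C@@]1(C)CC[C@@H]2C3=C1CC[C@@H](C)[C@]3(C)C[C@@H]1c3cccc(Br)c3N[C@H]21` differs from compound 1 by bromo in place of hydrogen on an aromatic carbon of a six-membered aromatic ring of carbon only, part of a fused or bridged system of five rings, ortho to a fused ring and meta to a fused ring.

Among the measured compounds shown here, two measured steps bear on this change, both a halogen for hydrogen on the same ring: a 1.0-fold lower number from compound 1 to compound 2 (0.02 log units; within the scatter) and a 1.6-fold lower number from compound 1 to compound 3 (0.19 log units; within the scatter). Neither moved the number beyond the scatter. For the measured compounds named here, the bromo in compound 4 enters at a different carbon from the chloro or fluoro, so its step has no exact precedent, but nothing known argues for a move in this assay. The expected step is therefore a 1.1-fold lower number from compound 1 to compound 4 (0.05 log units; within the scatter), none beyond the scatter. For compound 4 the estimate in this assay is 45000 nM, expected to fall between 20000 nM and 100000 nM.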

Compound 4, concentration for 50% growth inhibition: 54000 nM
Compound 4: the middle estimate sits 1.2-fold (0.08 log units) below what was measured, and the stated range covers the measured number.
By their numbers in this assay, from the lowest: compounds 3, 2, 1 and 4 (each within the scatter of the next).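

Bromo in place of hydrogen gives a 1.1-fold higher number from compound 1 to compound 4 (0.03 log units; within the scatter) in this assay at an aromatic carbon ortho to a fused ring and meta to a fused ring. The earlier compounds shown here covered only chloro and fluoro at one other carbon of this ring, so a second carbon and a third halogen now also leave the number within the scatter of the parent. Across compounds 2, 3 and 4, every halogen-for-hydrogen step on this ring stays within the scatter, none of the three goes against this, and halogen exchange on this ring has not yet separated any compound from compound 1.

Nothing available explains why the number stays put at this carbon.

Still open, as far as these compounds go, is whether a group other than a halogen at this carbon, such as an amine, a carboxylic acid or a methoxy group, would move the number beyond the scatter. Also open, from the compounds shown here alone, is whether chloro or fluoro at this carbon, or bromo at the carbon carrying them in compounds 2 and 3, would read the same way.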